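Fluorinated Methoxyphenyl Analogue of an Inactive Chalcone Pair

The source may report more compounds than this note shows. Statements on the series, on what has been measured and on what is new or still open speak of the compounds shown alone.

Compound 1 `COc1cccc(/C=C/C(=O)c2ccc(OC)c3c2OC(C)(C)C=C3)c1` carries a 3-methoxyphenyl group on its double-bonded chain. In a functional assay on HepG2 cells (Homo sapiens) for antiproliferative activity, read by MTT assay, with a stated time of 24 h (a lower number here means a stronger inhibitor, a higher number a weaker inhibitor), compound 1 gives > 10000 nM, which is a limit of the assay rather than a measured number. Compound 2 `COc1ccc(C(=O)/C=C/c2cc(OC)c(OC)c(OC)c2)c2c1C=CC(C)(C)O2` shares the same core but bears a differently substituted phenyl ring on the chain. In this assay compound 2 gives > 10000 nM, again a limit rather than a number. The two measured values share (the limit of > 10000 nM in this assay, at which 2 of the 2 values shown sit), so nothing in the data sets either compound apart from the other.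

Compound 3 `COc1ccc(/C=C/C(=O)c2ccc(OC)c3c2OC(C)(C)C=C3)c(F)c1` is the unmeasured analogue. It differs from compound 1 by 2-fluoro-4-methoxyphenyl in place of 3-methoxyphenyl on a double-bonded chain carbon bound to a double-bonded chain carbon. Going by the values given here, no measured step of this kind exists among the compounds described here, so any expectation rests only on the fact that both measured values are limits. On that basis a step that the limit leaves unreadable from compound 1 to compound 3 is expected to be small, with no change beyond the usual scatter. Compound 3 is therefore estimated to give 15000 nM, within a range from 5000 nM to 50000 nM, and most likely to be reported once more as a limit.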

Compound 3, half-maximal inhibitory concentration: 7560 nM
Beside the measured number, compound 3's estimate is 2.0-fold (0.30 log units) above it, and the stated range covers the measured number.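

In this assay, going by these compounds alone, compound 3 gives 7560 nM, the first value in this small set that is an actual number and not a limit, so this series can produce a readable result in this assay. Compound 1 remains a limit of the assay and not a number, as does compound 2: the limit of > 10000 nM in this assay, at which 2 of the 3 values shown sit. Placing 2-fluoro-4-methoxyphenyl in place of 3-methoxyphenyl on a double-bonded chain carbon bound to a double-bonded chain carbon gives an at least 1.3-fold lower number from compound 1 to compound 3 (0.12 log units; that floor lies within the scatter), so this change can be read only as a floor, and the true size of the step stays unknown, with the data so far showing no difference beyond the scatter.

This single step changes two things at once, adding a fluorine and giving a methoxy group at the 4 rather than the 3 position of the phenyl ring, and the compounds shown cannot separate the two. They also leave open how this position would respond to quite different groups, such as an amine or a carboxylic acid on the phenyl ring.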